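Aryl amine variation on the acrylamide series

The source may hold more compounds than are shown below. What is called first, only, known or untested is meant among the compounds shown, and "the series" means these compounds.

Compound 2 `C=CC(=O)Nc1cccc(NC(=O)CSc2nc(Nc3cccc(C)c3)c3ccccc3n2)c1` in a functional assay on NCI-H1975 cells (Homo sapiens) for inhibition, read by MTT assay, with a stated time of 72 h (on this read-out lower numbers stand for stronger inhibition and higher numbers for weaker inhibition), gives 12100 nM, the highest of the two numbers on record. Among the measured compounds shown here, compound 1 `C=CC(=O)Nc1cccc(NC(=O)CSc2nc(Nc3ccccc3C)c3ccccc3n2)c1` in this assay gives 9920 nM; the only measured step, a 1.2-fold higher number from compound 1 to compound 2 (0.09 log units; within the scatter), changes nothing beyond the scatter, so the two compounds read as one value.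

Compound 3 `C=CC(=O)Nc1cccc(NC(=O)CSc2nc(Nc3ccc(F)cc3)c3ccccc3n2)c1` is not yet measured. Its difference from compound 2 is 4-fluorophenyl in place of 3-methylphenyl on a nitrogen on an aromatic ring. For the measured compounds named here, no measured step covers a methyl-to-fluorine swap on this ring; the step from compound 1 to compound 2 only shows that moving the methyl on the same ring left the number unchanged, which is weak support for the view that the aryl group on this nitrogen is not where the potency is decided. Going by the values given here, with that as the sole guide, the step of a 1.1-fold lower number from compound 2 to compound 3 (0.04 log units; within the scatter) is expected to remain within the scatter, in no settled direction. Among the compounds with values here, compound 3 is therefore estimated at 11000 nM, with a range from 4000 nM to 35000 nM, the width reflecting the single indirect precedent.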

Compound 3, half-maximal inhibitory concentration: 4430 nM
For compound 3 the middle estimate is 2.5-fold (0.39 log units) above the measured one, and the stated range covers the measured number.
By their numbers in this assay, from the lowest: compound 3; then compounds 1 and 2 (each within the scatter of the next).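

In this assay the aryl group on the nitrogen on an aromatic ring now moves the number: 4-fluorophenyl gives a 2.7-fold lower number from compound 2 to compound 3 (0.44 log units; beyond the scatter) and a 2.2-fold lower number from compound 1 to compound 3 (0.35 log units; beyond the scatter) as two modest steps, where the two methylphenyl groups alone had shown no separation. This position is therefore not silent, though the finding rests on compound 3 alone, and each step changes both the substituent and its place on the ring, so the two changes cannot be told apart. No available evidence bears on the reason for these steps.

Still open, from the compounds shown here alone, is whether the fluorine or its place carries the step, which a methylphenyl with its methyl where 4-fluorophenyl carries its fluorine would help to separate. Also open, going by these compounds, is how far the trend goes with other groups on this nitrogen, such as a chlorophenyl, a methoxyphenyl or a cyclohexyl in place of the aromatic ring, and whether the step holds when the acrylamide end of the series is changed.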